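This account rests on a few compounds, and the source may have more. Where it says the series, first, only, none or still open, it means among the compounds named here.

Compound 1 `Cc1cnc(C(=O)Oc2ccc(C(N)=S)cc2)c[n+]1[O-]` gives > 800000 nM
Compound 2 `O=C(CCCCC1CCSS1)OCCCOC(=O)c1cccnc1` gives > 800000 nM
Compound 3 `Cc1ccc(NC(=S)OCCNC(=O)C(C)(C)Oc2ccc(Cl)cc2)cc1` gives > 800000 nM

In an ADME assay on RAW264.7 cells (Mus musculus) for cytotoxicity, read by MTT assay, with a stated time of 48 h (a higher number here means a weaker inhibitor, a lower number a stronger inhibitor), compound 2 gives > 800000 nM, which is a limit of the assay and not a number. It shares this reading with the other two compounds, as the limit of > 800000 nM in this assay, at which 3 of the 3 values shown sit, shows. Compound 4 `Cc1cnc(C(=O)OCCCOC(=O)CCCCC2CCSS2)c[n+]1[O-]` follows from compound 2 by one structural change: a group of 8 heavy atoms (5 carbon, 2 nitrogen, 1 oxygen; one six-membered aromatic ring with 2 hetero atoms) in place of a group of 6 heavy atoms (5 carbon, 1 nitrogen; one six-membered aromatic ring with 1 hetero atom), on a carbonyl carbon. Compound 1 carries the same entering group and gives > 800000 nM, again a limit. Going by the values given here, no step between measured compounds is available, and no step beyond the scatter is expected in this assay. The estimated change is a number no higher from compound 2 to compound 4 (the limit leaves the size open). Compound 4 is expected at 800000 nM, with an estimated range from 500000 nM to 1300000 nM.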

Compound 4, half-maximal inhibitory concentration: > 800000 nM
Compound 4: only a limit was reported; the forecaster's own chance of this, stated with the estimate: 85%; the middle value lies on the limit itself.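

In this assay, compound 2 and compound 4 each give only a limit of the assay, and no step can be read between them. The compounds shown leave open how toxic any of them actually is to these cells.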